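Stepwise Methoxy Additions on a Shared Core

A few compounds are considered here, and "the series" means these few. Any claim that something is new, unique, unknown or untested is made for them only; others in the source may bear on it.

Measured compounds in a functional assay on A549 cells (Homo sapiens) for cytotoxicity, read by MTT assay, with a stated time of 24 h; on this read-out higher numbers stand for weaker inhibition and lower numbers for stronger inhibition:
compound 1 `C/C(=N\NC(=O)/C(C#N)=C/c1ccc(O)cc1)c1c(O)c2ccc(O)cc2oc1=O`: 6230 nM
compound 2 `COc1cc(/C=C(\C#N)C(=O)N/N=C(\C)c2c(O)c3ccc(O)cc3oc2=O)ccc1O`: 12600 nM
compound 3 `COc1ccc(/C=C(\C#N)C(=O)N/N=C(\C)c2c(O)c3ccc(O)cc3oc2=O)cc1OC`: 14300 nM

Compound 4 `COc1cc(/C=C(\C#N)C(=O)N/N=C(\C)c2c(O)c3ccc(O)cc3oc2=O)cc(OC)c1OC` is not yet measured. It differs from compound 3 by methoxy in place of hydrogen on an aromatic carbon. The same kind of change separates compound 1 from compound 2, namely (methoxy in place of hydrogen on an aromatic carbon), and there it made a 2.0-fold higher number from compound 1 to compound 2 (0.31 log units; beyond the scatter). The two places are not identical: in compound 1 the entering group sits ortho to a hydroxy group, whereas in compound 3 it sits ortho to a methoxy group and meta to a methoxy group. The cores themselves differ by 3,4-dimethoxyphenyl in place of 4-hydroxyphenyl on a double-bonded chain carbon bound to a double-bonded chain carbon. Resting on the step from compound 1 to compound 2, the change from compound 3 to compound 4 is expected to give a 1.5-fold higher number from compound 3 to compound 4 (0.19 log units; within the scatter). Compound 4 is therefore estimated at 22000 nM, with a range from 9000 nM to 50000 nM.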

Compound 4, half-maximal inhibitory concentration: 15300 nM
Estimate against measurement, compound 4: 1.4-fold (0.16 log units) above; the measured number falls inside the stated range.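

Methoxy in place of hydrogen on an aromatic carbon made a 1.1-fold higher number from compound 3 to compound 4 (0.03 log units; within the scatter) in this assay and so left the number essentially unmoved on this core. Set beside the earlier step, the same change cannot be told apart on the two cores: the same change on two cores in this assay, a 2.0-fold higher number (0.31 log units; beyond the scatter) from compound 1 to compound 2 and a 1.1-fold higher number (0.03 log units; within the scatter) from compound 3 to compound 4, 1.9-fold (0.28 log units) apart, within the scatter of two such steps. This fits a single effect carried from one core to the other, but two steps, only one of them beyond the scatter, do not show that the change keeps a fixed size on either core or reaches any further core.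

The compounds shown leave open what an amine, a carboxylic acid or a longer chain would do on this aromatic carbon. They also leave open whether the same change would behave alike on a core carrying no methoxy group.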